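The compounds below may be only part of what the source reports. "The series", "measured", "known", "first", "only" and "open" are said of these compounds alone.

Compound 1 `Nc1cc(N)c2nc(-c3ccccc3)c(Oc3ccc(Cl)c(Cl)c3)nc2c1` is measured in a functional assay on OVCAR-3 cells (Homo sapiens) for inhibition, read by sulforhodamine B assay, with a stated time of 48 h (on this read-out higher numbers stand for weaker inhibition of growth and lower numbers for stronger inhibition of growth), where compound 1 gives 10700 nM. Among the three numbers recorded it is the highest. Among the compounds with values here, compound 2 `COc1ccc(CNc2nc3cc(N)cc(N)c3nc2-c2ccccc2)cc1OC` gives 1320 nM in this assay, and compound 3 `COc1cc(CNc2nc3cc(N)cc(N)c3nc2-c2ccccc2)cc(OC)c1OC` gives 1150 nM; both carry a benzylamine in place of the aryl ether of compound 1, and no step between them and compound 1 has been worked out, so only the values themselves can be set side by side. Within the data shown here, the one step that is worked out, a 1.1-fold lower number from compound 2 to compound 3 (0.06 log units; within the scatter), concerns a methoxy on the benzylamine and does not touch the position changed here.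

Compound 4 `Nc1cc(N)c2nc(-c3ccccc3)c(Sc3ccc(F)cc3)nc2c1` differs from compound 1 in one place: (4-fluorophenyl)sulfanyl in place of 3,4-dichlorophenoxy on an aromatic carbon. Among the measured compounds shown here, nothing among the measured steps speaks to an exchange of this kind, so no direction can be drawn from them. On that basis compound 4 is expected to lie close to compound 1, the estimated step being a 1.3-fold lower number from compound 1 to compound 4 (0.13 log units; within the scatter) and no larger than the scatter. The estimate for compound 4 in this assay is 8000 nM, with a range from 2000 nM to 32000 nM.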

Compound 4, concentration for 50% growth inhibition: 16200 nM
For compound 4 the middle estimate is 2.0-fold (0.31 log units) below the measured one; the measured number falls inside the stated range.
By their numbers in this assay, from the lowest: compounds 3 and 2 (each within the scatter of the next); then compounds 1 and 4 (each within the scatter of the next).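

In this assay the first exchange read at this aromatic carbon next to the ring nitrogen gives a 1.5-fold higher number from compound 1 to compound 4 (0.18 log units; within the scatter), so compound 1 and compound 4 cannot be told apart. The step replaces 3,4-dichlorophenoxy with (4-fluorophenyl)sulfanyl as a whole, so the linking atom and the halogens on the ring change together, and the shown result holds only for this pair and cannot be assigned to either part. No evidence bearing on this result is available.

On these data alone, it remains open whether a phenoxy group carrying only the 4-fluoro substituent, or a phenylsulfanyl group carrying the 3,4-dichloro pattern, would match these two compounds. Also open, as far as these compounds go, is how this position would respond to a directly attached amine, a sulfonyl link or a carboxylic acid on the ring.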